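Methoxy to hydroxy: an estimate for compound 3

This account rests on a few compounds, and the source may have more. Where it says the series, first, only, none or still open, it means among the compounds named here.

In a functional assay on A549 cells (Homo sapiens) for antiproliferative activity (a higher number here means a weaker inhibitor of growth, a lower number a stronger inhibitor of growth), compound 1 (`CC/C=C\[C@H](C)[C@H](OC(N)=O)[C@@H](C)[C@H](O)[C@@H](C)C/C(C)=C\[C@H](C)[C@@H](O)[C@@H](C)/C=C\[C@@H](O)C[C@@H]1OC(=O)[C@H](C)C[C@H]1C`) gives 11 nM and compound 2 (`CC/C=C\[C@H](C)[C@H](OC(N)=O)[C@@H](C)[C@H](O)[C@@H](C)C/C(C)=C\[C@H](C)[C@@H](O)[C@@H](C)/C=C\[C@@H](O)C[C@@H]1OC(=O)[C@H](C)[C@@H](OC)[C@H]1C`) gives 6.5 nM as its value. Compound 2 thus stands within the scatter of compound 1 and has no real separation from it. Compound 3 (`CC/C=C\[C@H](C)[C@H](OC(N)=O)[C@@H](C)[C@H](O)[C@@H](C)C/C(C)=C\[C@H](C)[C@@H](O)[C@@H](C)/C=C\[C@@H](O)C[C@@H]1OC(=O)[C@H](C)[C@@H](O)[C@H]1C`) has hydroxy where compound 2 has methoxy, with hydrogen in place of methyl on an oxygen on a saturated carbon. Within the data shown here, only one measured step bears on this, and only indirectly: methoxy in place of hydrogen on a saturated ring carbon gave a 1.7-fold lower number from compound 1 to compound 2 (0.23 log units; within the scatter) with no hydroxy compound yet measured. On that evidence, no step beyond the scatter is expected in this assay for compound 3. The estimated step is a 1.4-fold higher number from compound 2 to compound 3 (0.14 log units; within the scatter) and its direction is uncertain. Compound 3 is expected at 9 nM with an estimated range from 3.5 nM to 25 nM as its upper end.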

Compound 3, concentration for 50% growth inhibition: 7 nM
Compound 3: middle estimate off by 1.3-fold (0.11 log units), on the high side, and the stated range covers the measured number.
By their numbers in this assay, from the lowest: compounds 2, 3 and 1 (each within the scatter of the next).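

Taking the methyl off that oxygen on a saturated carbon gives a 1.1-fold higher number from compound 2 to compound 3 (0.03 log units; within the scatter) in this assay and so leaves methoxy and hydroxy indistinguishable at this position. The hydroxy group read against plain hydrogen on the saturated ring carbon gives a 1.6-fold lower number from compound 1 to compound 3 (0.20 log units; within the scatter) and so extends what the earlier pair showed for methoxy alone: hydrogen, methoxy and hydroxy here all lie within the scatter of one another. Nothing available here speaks to why these three compounds agree.

As far as these compounds go, whether this tolerance extends to other groups at the same place remains open, for instance an amine, a carboxylic acid or a longer chain such as butoxy. The three compounds also leave open whether the agreement would hold in any cell line other than this one.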